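The compounds below may be only part of what the source reports. "The series", "measured", "known", "first", "only" and "open" are said of these compounds alone.

Measured so far in an assay on isolated protein for inhibition of 3-hydroxy-3-methylglutaryl-coenzyme A reductase (Rattus norvegicus); a lower number here means a stronger inhibitor, a higher number a weaker inhibitor:

compound 3 `Cc1cc(Cl)c2ccc(Cl)cc2c1CCC1C[C@@H](O)CC(=O)O1`: 60 nM
compound 2 `Cc1cc(Cl)c(CCC2C[C@@H](O)CC(=O)O2)c2cc(Cl)ccc12`: 130 nM
compound 1 `Cc1ccc2c(C)cc(C)c(CCC3C[C@@H](O)CC(=O)O3)c2c1`: 360 nM

Compound 3 stands as the strongest inhibitor of the three, beyond the scatter from compound 2 and further still from compound 1, which carries only methyl groups on the shared core. Compound 4 `Cc1cc(C)c2ccc(Cl)cc2c1CCC1C[C@@H](O)CC(=O)O1` differs from compound 3 in one place: methyl in place of chloro on an aromatic carbon. Within the data shown here, no measured pair shows this exact change, but compound 1, with methyl throughout, sits well above compound 3 in this assay, so a modest loss is expected. The step from compound 3 to compound 4 is estimated at a 2.0-fold higher number from compound 3 to compound 4 (0.30 log units; within the scatter), a change around the edge of the scatter. Compound 4 is expected near 120 nM, within 50 nM to 300 nM.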

Compound 4, half-maximal inhibitory concentration: 200 nM
Compound 4: middle estimate off by 1.7-fold (0.22 log units), on the low side, within the range that was stated.
By their numbers in this assay, from the lowest: compound 3; then compounds 2, 4 and 1 (each within the scatter of the next, the first and the last beyond it).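

Methyl in place of chloro at the aromatic carbon para to a large group gives a 3.3-fold higher number from compound 3 to compound 4 (0.52 log units; beyond the scatter) in this assay, so chloro at this position is favoured over methyl when compared directly. The same exchange elsewhere on the shared core gives a 1.5-fold higher number from compound 2 to compound 4 (0.19 log units; within the scatter) and stays within the scatter. Chloro in place of methyl at a further place gives a 1.8-fold lower number from compound 1 to compound 4 (0.26 log units; within the scatter) and also stays within the scatter.

Nothing measured bears on why this position differs. Going by these compounds, whether bromo, methoxy or plain hydrogen at this carbon would match chloro remains open.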